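Hydroxy in Place of Hydrogen: an Expected Loss of Activity

The source may report more compounds than this note shows. Statements on the series, on what has been measured and on what is new or still open speak of the compounds shown alone.

Measured in a functional assay on A549 cells (Homo sapiens) for antiproliferative activity, read by MTT assay, with a stated time of 48 h (on this read-out higher numbers stand for weaker inhibition and lower numbers for stronger inhibition), so far:
Compound 1 `O=c1cc(-n2cc(COc3ccc(F)cc3)nn2)c2cc(Br)ccc2o1`: 850 nM
Compound 2 `O=c1cc(-n2cc(COc3ccccc3)nn2)c2cc(O)ccc2o1`: > 50000 nM (a limit of the assay, not a number)
Compound 3 `O=c1cc(-n2cc(COc3ccc(F)cc3)nn2)c2ccccc2o1`: 680 nM

Among these, compound 3 has the lowest number, with compound 1 close by: a 1.3-fold lower number from compound 1 to compound 3 (0.10 log units; within the scatter), a change of bromo to hydrogen. For compound 2 the assay reports only a limit, > 50000 nM.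

The unmeasured compound 4 `O=c1cc(-n2cc(COc3ccc(F)cc3)nn2)c2cc(O)ccc2o1` differs from compound 3 by hydroxy in place of hydrogen on an aromatic carbon. Within the data shown here, no measured step isolates this exact change; the one measured step concerns another position and lies within the scatter. Compound 2, however, carries the same hydroxy group and reaches only a limit, so a large rise in the number is anticipated. Compound 4 is therefore expected to give 30000 nM, in the range 4000 nM to 150000 nM, a step of a 44-fold higher number from compound 3 to compound 4 (1.64 log units; beyond the scatter), quite possibly reported only as a limit.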

Compound 4, half-maximal inhibitory concentration: 2010 nM
Compound 4: the middle estimate sits 15-fold (1.17 log units) above what was measured, and the stated range ends above it.
By their numbers in this assay, from the lowest: compounds 3 and 1 (each within the scatter of the next); then compound 4. At a limit, above all of these: compound 2.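

On the shared core, hydroxy on this aromatic carbon is tolerated: the rise is only modest (a 3.0-fold higher number from compound 3 to compound 4 (0.47 log units; beyond the scatter)), and the change from bromo is modest too (a 2.4-fold higher number from compound 1 to compound 4 (0.37 log units; beyond the scatter)). Compound 2 gives only a limit of the assay, not a number: the limit of > 50000 nM in this assay, at which 1 of the 4 values shown sits. With hydroxy kept in both compounds, fluoro in place of hydrogen on an aromatic carbon goes with a large drop (an at least 24-fold lower number from compound 2 to compound 4 (1.39 log units; beyond the scatter)), so hydroxy alone does not bring the number to that limit. Open, going by these compounds, is whether an amine or a methoxy group at this position would behave like hydroxy or like hydrogen.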